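From iodo to ethoxy on a shared core

The source may hold more compounds than are shown below. What is called first, only, known or untested is meant among the compounds shown, and "the series" means these compounds.

Compound 1 `C=C1C(=O)[C@]23C[C@@]1(Cl)CC[C@H]2[C@@]12C=CC(=O)[C@](C)(C(=O)O1)[C@H]2[C@@H]3C(=O)OCc1ccccc1` gives 28800 nM
Compound 2 `C=C1C(=O)[C@]23C[C@@]1(I)CC[C@H]2[C@@]12C=CC(=O)[C@](C)(C(=O)O1)[C@H]2[C@@H]3C(=O)OCc1ccccc1` gives 46000 nM
Compound 3 `C=C1C(=O)[C@]23C[C@@]1(OCC)CC[C@H]2[C@@]12C=CC(=O)[C@](C)(C(=O)O1)[C@H]2[C@@H]3C(=O)OCc1ccccc1` has not yet been measured

In a functional assay on A549 cells (Homo sapiens) for cytotoxicity, read by MTT assay (a lower number here means a stronger inhibitor, a higher number a weaker inhibitor), compound 2 gives 46000 nM and cannot be told apart from compound 1, whose 28800 nM lies within the scatter of it. Compound 3 differs from compound 2 as follows: ethoxy in place of iodo on a saturated ring carbon. In words, ethoxy takes the place of iodo on a saturated ring carbon. Among the measured compounds shown here, the only measured step bearing on this is a 1.6-fold higher number from compound 1 to compound 2 (0.20 log units; within the scatter) for iodo in place of chloro on a saturated ring carbon. For the measured compounds named here, no measured compound carries ethoxy, so that step is a limited guide. No step beyond the scatter is therefore expected in this assay, in either direction. The estimated step is a 1.3-fold lower number from compound 2 to compound 3 (0.12 log units; within the scatter) overall. Compound 3 is expected at about 35000 nM in an estimated range from 15000 nM to 80000 nM.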

Compound 3, half-maximal inhibitory concentration: 24200 nM
Estimate against measurement, compound 3: 1.4-fold (0.16 log units) above; measured number inside the range.
By their numbers in this assay, from the lowest: compounds 3, 1 and 2 (each within the scatter of the next).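

In this assay, ethoxy in place of iodo on this saturated ring carbon gives a 1.9-fold lower number from compound 2 to compound 3 (0.28 log units; within the scatter) and ethoxy in place of chloro gives a 1.2-fold lower number from compound 1 to compound 3 (0.08 log units; within the scatter). The earlier pair compared only two halogens, whereas compound 3 shows that iodo, with 1 heavy atom, and ethoxy, with 3 heavy atoms including an oxygen, still leave compounds that cannot be told apart at this position on the five-membered ring. No independent evidence is available to explain this result.

On these data alone, it remains open whether an amine, a carboxylic acid or a longer chain on this carbon would give a step beyond the scatter. All three compounds also share the rest of the core unchanged, so they cannot show how changes elsewhere on it would read in this assay.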